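This account rests on a few compounds, and the source may have more. Where it says the series, first, only, none or still open, it means among the compounds named here.

Among the compounds with values here, compound 3 `Fc1ccccc1Cn1nc(-c2nn[nH]n2)c2cccnc21` gives 8600 nM in a functional assay (aorta) with Oryctolagus cuniculus as the target (on this read-out higher numbers stand for weaker inhibition and lower numbers for stronger inhibition), the lowest of the three numbers so far, though its gap to compound 2 is within the scatter. Compound 2 `OCc1ccc(-c2nn(Cc3cccnc3)c3ccccc23)o1` gives 9600 nM in this assay; compound 1 `N#Cc1cccc(Cn2nc(-c3ccc(CO)o3)c3ccccc32)c1` gives 26000 nM in this assay, a gap from compound 3 beyond the scatter. Within the data shown here, the only measured step, a 2.7-fold lower number from compound 1 to compound 2 (0.43 log units; beyond the scatter), changes the group on the saturated chain carbon, not the group on the aromatic carbon of the core. Compound 4 `Nc1nc(-c2nn(Cc3ccccc3F)c3ncccc23)ncc1F` differs from compound 3 by 4-amino-5-fluoropyrimidin-2-yl in place of 2H-tetrazol-5-yl on an aromatic carbon. Among the measured compounds shown here, no measured step touches that position, so no shift beyond the scatter is expected, and the range is wide. Compound 4 is estimated at 9000 nM, between 2500 nM and 35000 nM. That expectation means a step of a 1.0-fold higher number from compound 3 to compound 4 (0.02 log units; within the scatter).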

Compound 4, half-maximal inhibitory concentration: 478000 nM
Compound 4: middle estimate off by 53-fold (1.73 log units), on the low side; the whole stated range lies below it.
By their numbers in this assay, from the lowest: compounds 3 and 2 (each within the scatter of the next); then compound 1; then compound 4.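

The group on this aromatic carbon of the core matters strongly in this assay: 4-amino-5-fluoropyrimidin-2-yl in place of 2H-tetrazol-5-yl gives a 56-fold higher number from compound 3 to compound 4 (1.74 log units; beyond the scatter) and so much weaker inhibition. Within the data shown here, the earlier step changed a different position, so this is the first view of this one. Both groups have the same hydrogen-bond donor and acceptor counts and no net charge, so these counts do not separate them, and no measurement here offers an explanation. As far as these compounds go, it remains open whether the rise comes from the six-membered ring itself, its amino group or its fluorine. From the compounds shown here alone, how a carboxylic acid or a simple amine would fare on this carbon also remains open.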